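This account rests on a few compounds, and the source may have more. Where it says the series, first, only, none or still open, it means among the compounds named here.

Within the data shown here, compound 2 `Nc1nc(NCc2ccco2)nc2sc(-c3ccco3)nc12` is one of two compounds measured so far in an assay on CHO cells for displacement of a labelled ligand from adenosine receptor A1 (Homo sapiens), read by scintillation counting, with a stated time of 90 min (on this read-out lower numbers stand for stronger inhibition and higher numbers for weaker inhibition), and in that assay compound 2 gives 38 nM. Among the measured compounds shown here, of the two numbers it holds the lower one, yet its only neighbour, compound 1 `Nc1nc(NCc2ccncc2)nc2sc(-c3ccco3)nc12`, is close: compound 1 gives 47 nM, and the change from compound 1 to compound 2 amounts to a 1.2-fold lower number from compound 1 to compound 2 (0.09 log units; within the scatter), so the two cannot be told apart on this read-out.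

Compound 3 `Nc1nc(NCc2ccccn2)nc2sc(-c3ccco3)nc12` is not yet measured. It differs from compound 2 in one place: pyridin-2-yl in place of furan-2-yl on a saturated chain carbon bound to a nitrogen on an aromatic ring. For the measured compounds named here, the single step that bears on this change is the one from compound 1 to compound 2, in which one aromatic heterocycle replaced another on the same saturated chain carbon and gave a 1.2-fold lower number from compound 1 to compound 2 (0.09 log units; within the scatter), a step within the scatter. By that precedent, the swap of one small aromatic heterocycle for another at this position is expected to leave the number about where it is, with a 1.2-fold higher number from compound 2 to compound 3 (0.07 log units; within the scatter) as the expected step. Compound 3 is therefore estimated at 45 nM, within a range from 18 nM to 110 nM.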

Compound 3, inhibition constant: 28 nM
Estimate against measurement, compound 3: 1.6-fold (0.21 log units) above; the measured number falls inside the stated range.
By their numbers in this assay, from the lowest: compounds 3, 2 and 1 (each within the scatter of the next).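

In this assay the replacement of the five-membered furan-2-yl by the six-membered pyridin-2-yl gives a 1.4-fold lower number from compound 2 to compound 3 (0.13 log units; within the scatter) and so adds a second heterocycle swap at this place that stays inside the scatter. Among these compounds, what the earlier compounds could not show is a comparison of two pyridine attachments: pyridin-2-yl in place of pyridin-4-yl gives a 1.7-fold lower number from compound 1 to compound 3 (0.22 log units; within the scatter) and so, on this read-out, the attachment point of the pyridine on the saturated chain carbon makes no difference that can be read, and all three groups remain indistinguishable. Nothing available accounts for this lack of separation or says what these groups do at the receptor.

The compounds shown all carry an aromatic heterocycle on this chain carbon, so they leave open whether a plain phenyl, a saturated ring such as cyclohexyl or piperidin-4-yl, or a longer chain between the ring and the amino nitrogen would keep the number in this range. They also leave open how far the furan-2-yl on the shared core and the free amine matter, since both stay the same throughout.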